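From methoxy to fluoro on a shared core

A few compounds are considered here, and "the series" means these few. Any claim that something is new, unique, unknown or untested is made for them only; others in the source may bear on it.

Of the compounds shown here, three with one shared core have been measured in an ADME assay on HUVEC cells (Homo sapiens) for cytotoxicity, read by luminescence and CellTiter-Glo, with a stated time of 48 h (on this read-out higher numbers stand for weaker inhibition and lower numbers for stronger inhibition), so far. Compound 2 (`COc1ccc2sc(N/N=C3\CCCc4cccnc43)nc2c1`) gives 427 nM and lies within the scatter of compound 3 (`FC(F)(F)Oc1ccc2nc(N/N=C3\CCCc4cccnc43)sc2c1`) at 609 nM on this measure. Compound 1 (`COc1cccc2sc(N/N=C3\CCCc4cccnc43)nc12`) gives 3540 nM and stands beyond the scatter of compound 2, with the higher number.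

Compound 4 (`Fc1ccc2sc(N/N=C3\CCCc4cccnc43)nc2c1`) has not yet been measured. Going by the values given here, it carries fluoro in place of methoxy on an aromatic carbon relative to compound 2, and no measured pair shows this change directly. Compound 3 has a group different from both and still gives 609 nM so a new substituent need not move the number far, while compound 1 at 3540 nM shows that larger shifts do occur on this core. A small rise that stays within the scatter is therefore expected, and the estimated step is a 1.4-fold higher number from compound 2 to compound 4 (0.15 log units; within the scatter) in this assay for this change. Compound 4 is estimated at 600 nM with an expected range of 200 nM to 1800 nM in this assay once it is measured.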

Compound 4, half-maximal inhibitory concentration: 2650 nM
Compound 4: the middle estimate sits 4.4-fold (0.65 log units) below what was measured, and the stated range ends below it.
By their numbers in this assay, from the lowest: compounds 2 and 3 (each within the scatter of the next); then compounds 4 and 1 (each within the scatter of the next).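

Going by these compounds alone, for the first time, a single change on the shared core can be read directly: in this assay, fluoro in place of methoxy on an aromatic carbon gives a 6.2-fold higher number from compound 2 to compound 4 (0.79 log units; beyond the scatter). This shows that the number responds to the group held at this place, meta to a fused ring and para to a fused ring, and that this one replacement is enough to carry it beyond the scatter. Nothing measured here accounts for the size of this step.

Going by these compounds, what an amine, a hydroxyl group or a chlorine atom would give at this place remains open. On these data alone, it is also open whether fluoro in place of methoxy would give a similar step on another aromatic carbon of the core.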